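Methyl in place of fluoro on compound 2

A few compounds are considered here, and "the series" means these few. Any claim that something is new, unique, unknown or untested is made for them only; others in the source may bear on it.

Measured so far:
compound 1 `CC(O)(C(=O)Nc1cccc(S(=O)(=O)c2ccccc2)c1)C(F)(F)F`: > 30000 nM
compound 2 `CC(O)(C(=O)Nc1ccc(C(=O)c2ccccc2)cc1F)C(F)(F)F`: 11000 nM

In a functional assay (Cavia porcellus) with sulfonylurea receptors; K-ATP channels (Homo sapiens) as the target (a higher number here means a weaker inhibitor, a lower number a stronger inhibitor), compound 1 reaches only a limit, > 30000 nM, (the limit of > 30000 nM in this assay, at which 1 of the 2 values shown sits). Within the data shown here, compound 2 gives 11000 nM in this assay and is the only compound with a number. The value of compound 1 in this assay is a limit. Compound 3 `Cc1cc(C(=O)c2ccccc2)ccc1NC(=O)C(C)(O)C(F)(F)F` differs from compound 2 by methyl in place of fluoro on an aromatic carbon. Among the measured compounds shown here, no step between measured compounds is available, so no direction is indicated; the change is expected to move this assay by no more than the scatter. Compound 3 is expected at 10000 nM, between 3500 nM and 30000 nM. That estimate means an expected step of a 1.1-fold lower number from compound 2 to compound 3 (0.04 log units; within the scatter).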

Compound 3, half-maximal inhibitory concentration: 5000 nM
For compound 3 the middle estimate is 2.0-fold (0.30 log units) above the measured one; the measured number falls inside the stated range.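

Methyl in place of fluoro on this aromatic carbon, ortho to a large group, gives a 2.2-fold lower number from compound 2 to compound 3 (0.34 log units; beyond the scatter) in this assay. This position is therefore not silent: an exchange of one heavy atom for one heavy atom, with no change in hydrogen-bond donors, acceptors or net charge, moves the read-out beyond the scatter. No measured property available here bears on the origin of this step.

As far as these compounds go, whether the step is specific to methyl remains open. Hydrogen, chlorine, an amine or a longer chain at this position would test that.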